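Capping a hydroxymethyl as a methyl ester on the shared core

This account rests on a few compounds, and the source may have more. Where it says the series, first, only, none or still open, it means among the compounds named here.

Compound 1 `CCOCc1ccc2c(c1)N(C)CC(C1=NCCN1)O2`: 17 nM
Compound 2 `CN1CC(C2=NCCN2)Oc2ccc(CO)cc21`: 100 nM

Compound 2 shows the higher of the two numbers measured in an assay on isolated protein for binding affinity to Nischarin (Homo sapiens); on this read-out higher numbers stand for weaker inhibition and lower numbers for stronger inhibition; its nearest neighbour is compound 1. Among the measured compounds shown here, the one step known so far, a 5.9-fold higher number from compound 1 to compound 2 (0.77 log units; beyond the scatter), was beyond the scatter. Compound 3 `COC(=O)c1ccc2c(c1)N(C)CC(C1=NCCN1)O2` carries methoxycarbonyl in place of hydroxymethyl on an aromatic carbon. That change, like the reverse of the known step, removes the hydrogen-bond donor on this arm of the core, so a modest step in this assay towards a lower number is expected, a 2.2-fold lower number from compound 2 to compound 3 (0.35 log units; beyond the scatter). The estimated value for compound 3 is 45 nM, expected within 12 nM to 150 nM.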

Compound 3, inhibition constant: 7 nM
Compound 3: the middle estimate sits 6.4-fold (0.81 log units) above what was measured; the measured number lies below the stated range.
By their numbers in this assay, from the lowest: compound 3; then compound 1; then compound 2.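

In this assay, this aromatic carbon responds strongly to the group it carries: replacing hydroxymethyl with methoxycarbonyl gives a 14-fold lower number from compound 2 to compound 3 (1.15 log units; beyond the scatter). The ester also outdoes the ether, with a 2.4-fold lower number from compound 1 to compound 3 (0.39 log units; beyond the scatter), so capping the hydroxyl is not the whole story and the identity of the capping group matters. No evidence here explains this difference. Going by these compounds, it remains open whether a carboxylic acid or an amide at this position would behave like the methyl ester. A longer ester chain, such as ethoxycarbonyl, could show whether the size of the ester's alkyl part matters.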